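Swapping the Sulfur Side Chain in a Level Series

The compounds below may be only part of what the source reports. "The series", "measured", "known", "first", "only" and "open" are said of these compounds alone.

Compound 1 `Cc1cc(Nc2cc(-c3ccccc3)[nH]n2)n2nc(SCc3ccc(Br)cc3)nc2n1`: 39300 nM
Compound 2 `Cc1cc(Nc2cc(-c3ccccc3)[nH]n2)n2nc(SCc3ccccc3Br)nc2n1`: 41100 nM
Compound 3 `Cc1cc(Nc2cc(-c3ccccc3)[nH]n2)n2nc(SCCCc3ccccc3)nc2n1`: 40200 nM

All three values come from an ADME assay on GES1 cells (Homo sapiens) for inhibition, read by MTT assay, with a stated time of 72 h; on this read-out lower numbers stand for stronger inhibition and higher numbers for weaker inhibition. Compound 3 stands level with the other two, as shown by a 1.0-fold lower number from compound 2 to compound 3 (0.01 log units; within the scatter) and by a 1.0-fold higher number from compound 1 to compound 3 (0.01 log units; within the scatter), so its place among them carries no meaning.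

The next compound, compound 4 `C#CCSc1nc2nc(C)cc(Nc3cc(-c4ccccc4)[nH]n3)n2n1`, keeps the shared core and differs at one place: ethynyl in place of phenethyl on a saturated chain carbon bound to a sulfur. In words, ethynyl stands in place of phenethyl on a saturated chain carbon bound to a sulfur, and the six-membered aromatic ring of carbon only leaves with it.

The measured steps that bear on this change are the same two, together with a 1.0-fold higher number from compound 1 to compound 2 (0.02 log units; within the scatter). All of them alter the group at this place, and none goes beyond the scatter. Yet every measured compound keeps an aromatic ring there, so the loss of that ring remains untested. The expectation therefore rests on compound 3 at 40200 nM, and no step beyond the scatter is expected in this assay, with the direction left open. The expected size is a 1.0-fold higher number from compound 3 to compound 4 (0.02 log units; within the scatter). For compound 4 the estimated value is 42000 nM, within an expected range of 18000 nM to 85000 nM.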

Compound 4, half-maximal inhibitory concentration: 45700 nM
Estimate against measurement, compound 4: 1.1-fold (0.04 log units) below, within the range that was stated.
By their numbers in this assay, from the lowest: compounds 1, 3, 2 and 4 (each within the scatter of the next).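

In this assay, among the compounds shown here, the loss of the six-membered aromatic ring of carbon only, which no earlier compound had tested, leaves the read-out level, with a 1.1-fold higher number from compound 3 to compound 4 (0.06 log units; within the scatter), a 1.1-fold higher number from compound 2 to compound 4 (0.05 log units; within the scatter) and a 1.2-fold higher number from compound 1 to compound 4 (0.07 log units; within the scatter). Among these four compounds, then, the group on a saturated chain carbon bound to a sulfur can go from phenethyl, 2-bromophenyl or 4-bromophenyl to ethynyl, with no ring left there, and no step leaves the scatter. Nothing at hand accounts for this flat response at the position.

From the compounds shown here alone, whether any group at this place can move the number beyond the scatter remains open, for instance an amine, a carboxylic acid or a longer chain ending in either one. All four compounds also keep the sulfur and the shared core, so the compounds shown cannot tell whether an oxygen in place of that sulfur, or a different group elsewhere on the core, would shift the value in this assay.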